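The source may report more compounds than this note shows. Statements on the series, on what has been measured and on what is new or still open speak of the compounds shown alone.

Of the compounds shown here, three have been measured in a functional assay on T-24 cells (Homo sapiens) for antiproliferative activity, read by MTT assay, with a stated time of 48 h; a higher number here means a weaker inhibitor, a lower number a stronger inhibitor.

Compound 1, `O=C(Nc1ccccc1)Nc1cccc(CNc2nccnc2Cl)c1`, gives 19800 nM.
Compound 2, `COc1ccc(NC(=O)Nc2cccc(CNc3nccnc3Cl)c2)cc1`, gives 9820 nM.
Compound 3, `COc1ccccc1NC(=O)Nc1cccc(CNc2nccnc2Cl)c1`, gives 10400 nM.

Compound 1 has the highest number of the three, yet neither neighbour is clearly apart from it: a 2.0-fold lower number from compound 1 to compound 2 (0.30 log units; within the scatter) and a 1.9-fold lower number from compound 1 to compound 3 (0.28 log units; within the scatter) both stay within the scatter. Compound 4, `Cc1ccc(NC(=O)Nc2cccc(CNc3nccnc3Cl)c2)c(C)c1`, differs from compound 1 by 2,4-dimethylphenyl in place of phenyl on an amide-type nitrogen. Within the data shown here, the steps that bear on this are the two methoxy-in-place-of-hydrogen steps from compound 1, each of which stayed within the scatter, so no more than a small step is expected in this assay, if anything toward a lower number. Compound 4 is therefore expected near 12000 nM, between 5000 nM and 30000 nM, which means an expected 1.7-fold lower number from compound 1 to compound 4 (0.22 log units; within the scatter).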

Compound 4, half-maximal inhibitory concentration: 9230 nM
Compound 4: middle estimate off by 1.3-fold (0.11 log units), on the high side, within the range that was stated.
By their numbers in this assay, from the lowest: compounds 4, 2, 3 and 1 (each within the scatter of the next, the first and the last beyond it).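

In this assay, 2,4-dimethylphenyl on the amide-type nitrogen gives the first step away from the phenyl of compound 1 that lies beyond the scatter, though only a modest one (a 2.1-fold lower number from compound 1 to compound 4 (0.33 log units; beyond the scatter)). Compound 4 cannot be told apart from the methoxy compounds (a 1.1-fold lower number from compound 3 to compound 4 (0.05 log units; within the scatter); a 1.1-fold lower number from compound 2 to compound 4 (0.03 log units; within the scatter)), so the two methyl groups and a single methoxy cannot be ranked here. No measurement at hand accounts for this step.

On these data alone, whether a single methyl group, an amine or a carboxylic acid on this ring would carry the number further from compound 1 stays open.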